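The source may hold more compounds than are shown below. What is called first, only, known or untested is meant among the compounds shown, and "the series" means these compounds.

In a functional assay on the whole organism (strain Wistar) for inhibition, with Rattus norvegicus as the target, read by paw edema, with stated times of 60 min and 3 h, at a dose of 100 mg/kg by the oral route (on this read-out higher numbers stand for more inhibition at the one dose given (going by the name of the read-out) and lower numbers for less inhibition), the three measured compounds read as follows: compound 1 `COc1cc2c(cc1OC)C(CC(=O)O)CC2` gives 27.5%; compound 2 `CNC(=O)CC1CCc2cc(OC)c(OC)cc21` gives 29%; compound 3 `COc1cc2c(cc1OC)C(CC(=O)N(C)C)CC2` gives 34.8%.

Within the data shown here, compound 3 holds the highest of the three numbers, yet its step from compound 2 is a number 5.8 percentage points higher from compound 2 to compound 3 (within the scatter) and from compound 1 a number 7.3 percentage points higher from compound 1 to compound 3 (within the scatter), both within the scatter, so no compound can be set above another. Compound 4 `CCN(CC)C(=O)CC1CCc2cc(OC)c(OC)cc21` differs from compound 3 by diethylamino in place of dimethylamino on a carbonyl carbon. The measured step that bears most on this change is a number 5.8 percentage points higher from compound 2 to compound 3 (within the scatter), a change at the same amide-type nitrogen; a number 1.5 percentage points higher from compound 1 to compound 2 (within the scatter) likewise stayed within the scatter. No step beyond the scatter is therefore expected. Compound 4 is expected to give 36%. The range for compound 4 is estimated from 24% to 48%. The expected step is a number 1.2 percentage points higher from compound 3 to compound 4 (within the scatter), within the scatter.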

Compound 4, a percentage reported as inhibition, in the whole organism at one dose (the size of the read-out at that dose, not a potency): 37.7%
Estimate against measurement, compound 4: 1.7 percentage points below; the range from low to high includes it.
By their numbers in this assay, from the lowest: compounds 1, 2, 3 and 4 (each within the scatter of the next, the first and the last beyond it).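

In this assay, diethylamino on the carbonyl carbon reads within the scatter of dimethylamino (a number 2.9 percentage points higher from compound 3 to compound 4 (within the scatter)) and of methylamino (a number 8.7 percentage points higher from compound 2 to compound 4 (within the scatter)), so the larger amine group does not separate from the smaller ones. Only the replacement of hydroxy (a number 10.2 percentage points higher from compound 1 to compound 4 (beyond the scatter)) lies beyond the scatter, modestly, which sets compound 4 alone among the amides apart from the acid compound 1. Nothing here bears on the reason for these numbers.

Open, from the compounds shown here alone, is how a ring amine such as piperidine or a longer chain such as dipropylamino would read at this position.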